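A few compounds are considered here, and "the series" means these few. Any claim that something is new, unique, unknown or untested is made for them only; others in the source may bear on it.

Measured in a functional assay on HepG2 cells (Homo sapiens) for inhibition, read by MTT assay, with a stated time of 72 h; a lower number here means a stronger inhibitor, a higher number a weaker inhibitor:
compound 1 `Nc1nc2cc(-c3nn(CCCCCCCCCC(=O)NO)c4ncnc(N)c34)ccc2o1` gives 28600 nM;
compound 2 `Nc1ncnc2c1c(-c1cnc3[nH]ccc3c1)nn2CCCCCCCCCC(=O)NO` gives 11700 nM;
compound 3 `Nc1nc2cc(-c3nn(CCCCCCCCC(=O)NO)c4ncnc(N)c34)ccc2o1` gives 2610 nM.

Compound 2 stands second highest of the three numbers, with a 2.4-fold lower number from compound 1 to compound 2 (0.39 log units; beyond the scatter) on one side and compound 3, the lowest of the set, on the other. Compound 4 `Nc1ncnc2c1c(-c1cnc3[nH]ccc3c1)nn2CCCCC(=O)NO` is not yet measured; it differs from compound 2 by hydroxycarbamoyl in place of 5-(hydroxycarbamoyl)pentyl on a saturated chain carbon, four bonds along the chain from an aromatic nitrogen. Among the compounds with values here, the only measured step that bears on chain length is an 11-fold lower number from compound 1 to compound 3 (1.04 log units; beyond the scatter), a large drop for a short cut of the chain. The change to compound 4 is a far longer cut along the same chain, well outside what that single step covers, so a lower number is expected, but its size is uncertain. Compound 4 is estimated at 3500 nM (range 700 nM to 18000 nM), which means a 3.3-fold lower number from compound 2 to compound 4 (0.52 log units; beyond the scatter) is expected.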

Compound 4, half-maximal inhibitory concentration: 36700 nM
Compound 4: middle estimate off by 10-fold (1.02 log units), on the low side, outside the stated range (above it).
By their numbers in this assay, from the lowest: compound 3; then compound 2; then compounds 1 and 4 (each within the scatter of the next).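

On the core of compound 2, hydroxycarbamoyl in place of 5-(hydroxycarbamoyl)pentyl gives a 3.1-fold higher number from compound 2 to compound 4 (0.50 log units; beyond the scatter) in this assay and so runs opposite to an 11-fold lower number from compound 1 to compound 3 (1.04 log units; beyond the scatter) on the core of compound 1. Shortening the chain therefore does not lower the number in every case, although these two steps differ in core and in the length removed. Still open, as far as these compounds go, is how chains of intermediate length on the core of compound 2 would read, and how a carboxylic acid in place of hydroxycarbamoyl would read. No evidence here accounts for the opposite directions of the two steps.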